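A few compounds are considered here, and "the series" means these few. Any claim that something is new, unique, unknown or untested is made for them only; others in the source may bear on it.

Measured compounds in a functional assay on B16 cells (Mus musculus) for cytotoxicity, read by MTT assay, with a stated time of 72 h; on this read-out higher numbers stand for weaker inhibition and lower numbers for stronger inhibition:
Compound 1, `COc1cc(OC)c(C2CC(c3cc(OC)ccc3OC)=NN2C(C)=O)c(OC)c1`, gives 69000 nM.
Compound 2, `COc1ccc(C2CC(c3cc(OC)c(OC)c(OC)c3)=NN2C(C)=O)cc1[N+](=O)[O-]`, gives only a limit of the assay, > 100000 nM.
Compound 3, `COc1ccc(C2CC(c3cc(OC)c(OC)c(OC)c3)=NN2)cc1OC`, gives 44000 nM.

Compound 3 holds the lowest of the two numbers in this assay; its nearest neighbour is compound 1, whose number sits slightly higher but within the scatter of the assay, so no order between the two can be read. Compound 2 contributes no number, only the limit described by the limit of > 100000 nM in this assay, at which 1 of the 3 values shown sits.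

Compound 4, `COc1cc(C2=NNC(c3cc(OC)c(OC)c(OC)c3)C2)cc(OC)c1OC`, has not been measured. It differs from compound 3 by methoxy in place of hydrogen on an aromatic carbon, giving both aromatic rings of the shared core the same trimethoxy substitution. Going by the values given here, no measured pair in this set shows the effect of such a change, so there is no basis for expecting a step beyond the scatter in this assay in either direction. The estimated step is a 1.1-fold higher number from compound 3 to compound 4 (0.06 log units; within the scatter), that is, essentially none. Compound 4 is therefore expected to give about 50000 nM in this assay, with a plausible range of 20000 nM to 100000 nM.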

Compound 4, half-maximal inhibitory concentration: 56000 nM
Compound 4: the middle estimate sits 1.1-fold (0.05 log units) below what was measured; the measured number falls inside the stated range.
By their numbers in this assay, from the lowest: compounds 3, 4 and 1 (each within the scatter of the next). At a limit, above all of these: compound 2.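

In this assay, the only pair shown that differs in one place gives a 1.3-fold higher number from compound 3 to compound 4 (0.10 log units; within the scatter), for methoxy in place of hydrogen on an aromatic carbon, ortho to a methoxy group and meta to a large group. A methoxy group at this position therefore makes no difference that can be told from the scatter, and the two compounds cannot be put in order. Nothing shown gives a cause for this outcome.

Whether this single pair holds for other groups at the same position stays open, since an amine, a hydroxyl or a fluorine there has no number among the compounds shown. Also open, going by these compounds, is whether the same methoxy change gives a similar step on a core bearing the acetyl group of compound 1.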